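From a Five-Membered Ring to a Methylated Six-Membered Ring

A few compounds are considered here, and "the series" means these few. Any claim that something is new, unique, unknown or untested is made for them only; others in the source may bear on it.

Three compounds share one core and differ only in the ring attached to the carbonyl carbon. Compound 1 `O=C(C1CC12CCC2)N1CCc2nc(C#Cc3ccccc3)sc2C1` gives 3.9 nM in an assay on HEK293 cells for positive allosteric modulation of metabotropic glutamate receptor 5 (Homo sapiens), read by FLIPR, with a stated time of 1 h; a lower number here means that less compound is needed, a higher number that more compound is needed for the effect. Compound 2 `CC1CC(C(=O)N2CCc3nc(C#Cc4ccccc4)sc3C2)C1` gives 81 nM in this assay, and compound 3 `O=C(C1CCCC1)N1CCc2nc(C#Cc3ccccc3)sc2C1` gives 19 nM. Compound 3 therefore stands second highest of the three numbers: there is a 4.3-fold lower number from compound 2 to compound 3 (0.63 log units; beyond the scatter), and there is a 4.9-fold higher number from compound 1 to compound 3 (0.69 log units; beyond the scatter).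

Compound 4 `CC1CCCC(C(=O)N2CCc3nc(C#Cc4ccccc4)sc3C2)C1` differs from compound 3 by 3-methylcyclohexyl in place of cyclopentyl on a carbonyl carbon. Among the compounds with values here, the steps that bear on this change are a 4.9-fold higher number from compound 1 to compound 3 (0.69 log units; beyond the scatter) and a 4.3-fold lower number from compound 2 to compound 3 (0.63 log units; beyond the scatter), both of modest size, showing that the ring on the carbonyl carbon moves the number well beyond the scatter. A six-membered ring carrying a methyl is not covered directly by any measured pair, so the direction is uncertain; a modest rise is expected, echoing a 4.3-fold lower number from compound 2 to compound 3 (0.63 log units; beyond the scatter) read in reverse. For compound 4 the estimated value in this assay is 40 nM, with a range from 10 nM to 160 nM, which amounts to an expected step of a 2.1-fold higher number from compound 3 to compound 4 (0.32 log units; beyond the scatter).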

Compound 4, half-maximal effective concentration: 100 nM
The estimate for compound 4 lay 2.5-fold (0.40 log units) below the measured number, within the range that was stated.
By their numbers in this assay, from the lowest: compound 1; then compound 3; then compounds 2 and 4 (each within the scatter of the next).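

In this assay there is a 5.3-fold higher number from compound 3 to compound 4 (0.72 log units; beyond the scatter) when 3-methylcyclohexyl replaces cyclopentyl on the carbonyl carbon, so this larger, methyl-bearing ring does not keep the number of compound 3. Between the two methyl-bearing rings the size of the ring makes no clear difference, with a 1.2-fold higher number from compound 2 to compound 4 (0.09 log units; within the scatter) when 3-methylcyclohexyl replaces 3-methylcyclobutyl, while a 26-fold higher number from compound 1 to compound 4 (1.41 log units; beyond the scatter) leaves the group of compound 1 far apart from the six-membered ring. No measurement shown here accounts for these steps.

From the compounds shown here alone, whether the step from compound 3 follows the added methyl or the larger ring remains open, and a plain cyclohexyl or a methylcyclopentyl group would separate the two. Going by these compounds, how an amine or a hydroxyl group on the ring would behave also remains open.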